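Swapping the Naphthalene Ether for a Trifluorophenyl Ether

A few compounds are considered here, and "the series" means these few. Any claim that something is new, unique, unknown or untested is made for them only; others in the source may bear on it.

Compound 1 `CC(C)[C@H](NC(=O)COc1cccc2ccccc12)C(=O)N[C@@H](CC(=O)O)C(=O)COc1ccc2ccccc2c1` was tested in a functional assay on Jurkat cells (Homo sapiens); a lower number here means a stronger inhibitor, a higher number a weaker inhibitor. In this assay compound 1 gives > 100000 nM, which is a limit of the assay rather than a number (the limit of > 100000 nM in this assay, at which 1 of the 3 values shown sits). Two related compounds have numbers: in this assay compound 2 `CC(C)[C@H](NC(=O)COc1cccc2ccccc12)C(=O)N[C@@H](CC(=O)O)C(=O)COc1ccc(-c2ccccc2)cc1` gives 87900 nM, and compound 3 `CC(C)[C@H](NC(=O)COc1cccc2ccccc12)C(=O)N[C@@H](CC(=O)O)C(=O)COc1ccc(OC(F)(F)F)cc1` gives 29100 nM. Both keep the shared core of compound 1 and change only the group on an oxygen on a saturated carbon, giving an at least 1.1-fold lower number from compound 1 to compound 2 (0.05 log units; that floor lies within the scatter) and an at least 3.4-fold lower number from compound 1 to compound 3 (0.53 log units; beyond the scatter); between the two of them the step is a 3.0-fold lower number from compound 2 to compound 3 (0.48 log units; beyond the scatter).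

Compound 4 `CC(C)[C@H](NC(=O)COc1cccc2ccccc12)C(=O)N[C@@H](CC(=O)O)C(=O)COc1ccc(F)c(F)c1F` takes the same place in a new direction: 2,3,4-trifluorophenyl in place of naphthalen-2-yl on an oxygen on a saturated carbon. Within the data shown here, the two steps away from compound 1 are what bear on it, and both point toward a lower number, the one to compound 3 clearly beyond the scatter. A modest lowering is therefore expected, closer to compound 3 than to compound 2. Compound 4 is expected to give 35000 nM, with a range from 12000 nM to 100000 nM. That expectation corresponds to an estimated step of an at least 2.8-fold lower number from compound 1 to compound 4 (0.45 log units; beyond the scatter).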

Compound 4, half-maximal inhibitory concentration: 35800 nM
For compound 4 the middle estimate is 1.0-fold (0.01 log units) below the measured one, within the range that was stated.
By their numbers in this assay, from the lowest: compounds 3 and 4 (each within the scatter of the next); then compound 2. At a limit, above all of these: compound 1.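

In this assay, 2,3,4-trifluorophenyl is a second group, after 4-(trifluoromethoxy)phenyl, that moves this position clearly away from naphthalen-2-yl, with an at least 2.7-fold lower number from compound 1 to compound 4 (0.44 log units; beyond the scatter). Compound 1 stands at a limit of the assay, not at a number: the limit of > 100000 nM in this assay, at which 1 of the 4 values shown sits.

These two groups share little beyond the phenyl ring yet cannot be told apart here, with a 1.2-fold higher number from compound 3 to compound 4 (0.09 log units; within the scatter), while 4-phenylphenyl remains separated from the trifluorophenyl group, with a 2.5-fold lower number from compound 2 to compound 4 (0.39 log units; beyond the scatter).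

The compounds shown leave open whether all three fluorines of 2,3,4-trifluorophenyl are needed, or whether plain phenyl or a phenyl ring with a single fluorine would give a similar number. They also leave open how a phenyl ring carrying an amine or a carboxylic acid would behave on this oxygen.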